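This account rests on a few compounds, and the source may have more. Where it says the series, first, only, none or still open, it means among the compounds named here.

In a functional assay on V79-379A cells (Cricetulus griseus) for cytotoxicity, read by MTT assay, in the presence of a further agent that is not named here (a lower number here means a stronger inhibitor, a higher number a weaker inhibitor), compound 1 `COC1=CC(=O)c2c(c(COC(=O)c3ccccc3F)c(C)n2C)C1=O` gives 2000 nM and compound 2 `CCOC(=S)Sc1c2c(n(C)c1C)C(=O)C=C(OC)C2=O` gives 3000 nM as the other number, so the two values lie within the usual scatter of each other. Compound 3 `COC1=CC(=O)c2c(c(COC(N)=O)c(C)n2C)C1=O` has not yet been measured. It carries (carbamoyloxy)methyl in place of the group on an aromatic carbon of compound 2 a group of 5 heavy atoms (2 carbon, 1 nitrogen, 2 oxygen; no ring) in place of a group of 6 heavy atoms (3 carbon, 1 oxygen, 2 sulfur; no ring), on an aromatic carbon and keeps the shared core. Among the measured compounds shown here, no measured step shows what such a change does, so no shift beyond the scatter is expected. The expected step of a 1.5-fold lower number from compound 2 to compound 3 (0.18 log units; within the scatter) is only an estimate. For compound 3 the estimated value is 2000 nM with an expected range of 500 nM to 8000 nM in this measurement.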

Compound 3, half-maximal inhibitory concentration: 300 nM
Compound 3: middle estimate off by 6.7-fold (0.82 log units), on the high side; the whole stated range lies above it.
By their numbers in this assay, from the lowest: compound 3; then compounds 1 and 2 (each within the scatter of the next).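

In this assay the group on this aromatic carbon proves able to move the number well beyond the scatter: (carbamoyloxy)methyl gives a 10-fold lower number from compound 2 to compound 3 (1.00 log units; beyond the scatter). Amino in place of 2-fluorophenyl on the carbonyl carbon, the only difference between these two compounds, gives a 6.7-fold lower number from compound 1 to compound 3 (0.82 log units; beyond the scatter), so that single change is enough. Nothing available accounts for either step. As far as these compounds go, whether methylamino or dimethylamino on that carbonyl carbon would hold the lower number remains open. So does what a plain hydroxymethyl on the aromatic carbon would give.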